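Extending the amide of compound 3 with a dihydroxypropyl chain

A few compounds are considered here, and "the series" means these few. Any claim that something is new, unique, unknown or untested is made for them only; others in the source may bear on it.

Measured so far:
compound 1, `CC1(C)CNC(=O)c2sc(Nc3ccc(I)cc3F)nc2C1`, 8870 nM
compound 2, `CC1(C)CNC(=O)c2sc(Nc3ccc(I)cc3F)c(C(=O)NC[C@H]3CCCN3)c2C1`, 120 nM
compound 3, `CC1(C)CNC(=O)c2sc(Nc3ccc(I)cc3Cl)c(C(N)=O)c2C1`, 596 nM

All three compounds share one core and were tested in a functional assay on HT-29 cells (Homo sapiens) for antiproliferative activity; on this read-out lower numbers stand for stronger inhibition and higher numbers for weaker inhibition. Compound 1 carries no side group on the core and gives 8870 nM, the highest number of the three. Compound 3, which carries a carbamoyl group and a chlorine on the aniline ring, gives 596 nM and stands second highest: its number lies beyond the scatter from both neighbours, lower than that of compound 1 and higher than that of compound 2, which gives 120 nM with a larger, ring-bearing amide substituent.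

Compound 4 is `CC1(C)CNC(=O)c2sc(Nc3ccc(I)cc3Cl)c(C(=O)NC[C@@H](O)CO)c2C1`. It differs from compound 3 by 2,3-dihydroxypropyl in place of hydrogen on an amide-type nitrogen. Among the measured compounds shown here, no single-point step between measured compounds exists to calibrate this change. Compound 2 shows that a substituted amide can go with a lower number than the plain carbamoyl of compound 3, although compound 2 also differs in its ring halogen. The expected outcome for compound 4 is therefore a moderate drop in the number, a 2.0-fold lower number from compound 3 to compound 4 (0.30 log units; within the scatter). Compound 4 is estimated at 300 nM, with a range from 100 nM to 900 nM.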

Compound 4, half-maximal inhibitory concentration: 710 nM
Estimate against measurement, compound 4: 2.4-fold (0.37 log units) below, within the range that was stated.
By their numbers in this assay, from the lowest: compound 2; then compounds 3 and 4 (each within the scatter of the next); then compound 1.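

In this assay, among the compounds shown here, placing 2,3-dihydroxypropyl on the amide-type nitrogen gives a 1.2-fold higher number from compound 3 to compound 4 (0.08 log units; within the scatter), and this is the first comparison in which only one place differs. It shows that the amide hydrogen of the carbamoyl group can be exchanged for this chain, with its two hydrogen-bond donors, two hydrogen-bond acceptors and one defined stereocentre, while the two numbers remain indistinguishable within the usual scatter, so this substituent gives no measurable gain or loss on this read-out. The data contain no measurement that could account for this outcome.

Going by these compounds, what remains open is whether a different group on the same nitrogen, such as a simple methyl, a 2-hydroxyethyl chain, a longer chain, or a chain ending in an amine or a carboxylic acid, would move the number beyond the scatter from that of compound 3. On these data alone, it is also open whether the opposite configuration at the stereocentre of the 2,3-dihydroxypropyl chain would give a number that differs from that of compound 4.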